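A Furanyl Replacement Tested for Cytotoxicity

The source may report more compounds than this note shows. Statements on the series, on what has been measured and on what is new or still open speak of the compounds shown alone.

Three compounds sharing one core have been examined in an ADME assay on HEK293 cells (Homo sapiens) for cytotoxicity, read by CellTiter-Glo and resazurin assay, with a stated time of 72 h; a lower number here means that less compound is needed, a higher number that more compound is needed for the effect. Compound 1 (`CC(C)N(Cc1cccc(OCCCCCC(=O)O)c1)C(=O)c1ccc(-c2cccc3ccccc23)cc1`) carries a naphthalen-1-yl group; in this assay compound 1 gives > 26000 nM, which is a limit of the assay. Compound 2 (`CC(=O)c1cccc(-c2ccc(C(=O)N(Cc3cccc(OCCCCCC(=O)O)c3)C(C)C)cc2)c1`) has 3-acetylphenyl in that place, and in this assay compound 2 gives > 26000 nM, again a limit. Compound 3 (`CC(C)COc1cccc(-c2ccc(C(=O)N(Cc3cccc(OCCCCCC(=O)O)c3)C(C)C)cc2)c1`) carries 3-(isobutoxy)phenyl; in this assay compound 3 gives > 26000 nM, also a limit. Compound 3 thus stands at the limit alongside the other two, as the limit of > 26000 nM in this assay, at which 3 of the 3 values shown sit, records. The steps between the measured compounds, a step that the two limits leave unreadable from compound 1 to compound 2, a step that the two limits leave unreadable from compound 1 to compound 3 and a step that the two limits leave unreadable from compound 2 to compound 3, are not readable in size; each of their ends is a limit.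

Compound 4 (`CC(C)N(Cc1cccc(OCCCCCC(=O)O)c1)C(=O)c1ccc(-c2ccoc2)cc1`) differs from compound 3 by furan-3-yl in place of 3-(isobutoxy)phenyl on an aromatic carbon. For the measured compounds named here, none of the measured steps can be read, so no size can be drawn from them; what they do show is that every measured exchange of this group left the value at the limit. Compound 4 is therefore expected to show no step beyond the scatter, a step that the limit leaves unreadable from compound 3 to compound 4. Compound 4 is estimated at 40000 nM, between 15000 nM and 150000 nM, and is expected most likely to be reported again only as a limit.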

Compound 4, half-maximal effective concentration: > 26000 nM
Compound 4: no number, only a limit; the forecaster's own chance of this, stated with the estimate: 85%; the middle value does not contradict the limit.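

In this assay compound 4 gives > 26000 nM as a limit of the assay. For the compounds shown here, no step from compound 1, compound 2 or compound 3 to compound 4 can be read, and all four compounds stand together: the limit of > 26000 nM in this assay, at which 4 of the 4 values shown sit. The compounds shown leave open at what concentration, if any, each would reach the half-maximal effect on these cells.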